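The compounds below may be only part of what the source reports. "The series", "measured", "known", "first", "only" and "open" are said of these compounds alone.

Measured so far in a functional assay on MCF7 cells (Homo sapiens) for inhibition, read by MTT assay; a higher number here means a weaker inhibitor, a lower number a stronger inhibitor:
compound 1 `CCCCCCCCn1cc(/C=C/C(=O)c2ccc(NC(=O)CN3CCN(c4ccccc4F)CC3)cc2)nn1` gives 68600 nM
compound 2 `O=C(CN1CCN(c2ccccc2F)CC1)Nc1ccc(C(=O)/C=C/c2cn(Cc3ccc(Br)cc3)nn2)cc1` gives 11300 nM
compound 3 `CCCCCCCCn1cc(/C=C/C(=O)c2ccc(NC(=O)CBr)cc2)nn1` gives 12900 nM

Compound 2 holds the lowest of the three numbers, but compound 3 sits within the scatter of it, so the two cannot be ordered; compound 1 stands clearly above both, the step from compound 1 to compound 2 being a 6.1-fold lower number from compound 1 to compound 2 (0.78 log units; beyond the scatter).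

Compound 4 `O=C(CN1CCN(c2ccc([N+](=O)[O-])cc2)CC1)Nc1ccc(C(=O)/C=C/c2cn(Cc3ccc(Br)cc3)nn2)cc1` has not been measured. It differs from compound 2 by 4-nitrophenyl in place of 2-fluorophenyl on an amine nitrogen in a ring. Among the measured compounds shown here, the only measured step, a 6.1-fold lower number from compound 1 to compound 2 (0.78 log units; beyond the scatter), concerns the group on the saturated chain carbon bound to an aromatic nitrogen, a different place from the amine nitrogen in the ring; compounds 1, 2 and 3 all carry the same 2-fluorophenyl there, or none of the piperazinyl part at all in compound 3. For the measured compounds named here, no measured step therefore bears on the change to compound 4, and no movement beyond the scatter is expected in this assay.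

Compound 4 is estimated at 12000 nM, with a range of 4000 nM to 36000 nM. This estimate means an expected step of a 1.1-fold higher number from compound 2 to compound 4 (0.03 log units; within the scatter), none beyond the scatter.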

Compound 4, half-maximal inhibitory concentration: 31600 nM
Estimate against measurement, compound 4: 2.6-fold (0.42 log units) below, and the stated range covers the measured number.
By their numbers in this assay, from the lowest: compounds 2 and 3 (each within the scatter of the next); then compound 4; then compound 1.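

In this assay, the first step read at the amine nitrogen in the ring is a 2.8-fold higher number from compound 2 to compound 4 (0.45 log units; beyond the scatter), so the aryl group at this place does move the number, though only modestly. Compounds 1 and 2 share 2-fluorophenyl there and compound 3 lacks that part, so none of them could show this. The change replaces fluorine with nitro and also alters where the group stands on the phenyl ring, so the step belongs to the two changes together, and no available evidence bears on its cause.

Open, as far as these compounds go, is whether 4-fluorophenyl, 2-nitrophenyl or unsubstituted phenyl would sit nearer compound 2 or compound 4, which would separate the group from its place on the ring. Also open, from the compounds shown here alone, is whether the step holds with the chain of compound 1 in place of the 4-bromophenyl group.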